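Compound 4: another alkyl change on the aromatic nitrogen

This account rests on a few compounds, and the source may have more. Where it says the series, first, only, none or still open, it means among the compounds named here.

In a functional assay on PC-3 cells (Homo sapiens) for cytotoxicity, read by WST assay, with a stated time of 3 days (a higher number here means a weaker inhibitor, a lower number a stronger inhibitor), compound 1 `CCCn1ccnc1/C=C/C(=O)/C=C/c1coc2ccccc2c1=O` gives 2400 nM, compound 2 `CCCCCn1ccnc1/C=C/C(=O)/C=C/c1coc2ccccc2c1=O` gives 2100 nM and compound 3 `CC(C)n1ccnc1/C=C/C(=O)/C=C/c1coc2ccccc2c1=O` gives 2300 nM. Compound 3 therefore stands within the scatter of both other compounds. The next change, to compound 4 `CC(C)CCn1ccnc1/C=C/C(=O)/C=C/c1coc2ccccc2c1=O`, is isopentyl in place of isopropyl on an aromatic nitrogen. For the measured compounds named here, three measured steps bear on it: a 1.1-fold lower number from compound 1 to compound 2 (0.06 log units; within the scatter), a 1.0-fold lower number from compound 1 to compound 3 (0.02 log units; within the scatter) and a 1.1-fold higher number from compound 2 to compound 3 (0.04 log units; within the scatter). All three lie within the scatter, so the propyl, pentyl and isopropyl compounds show no separation in this assay. No step beyond the scatter is expected here, and the estimated change is a 1.0-fold lower number from compound 3 to compound 4 (0.02 log units; within the scatter). The expected value for compound 4 is 2200 nM, with an estimated range of 1400 nM to 3400 nM.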

Compound 4, half-maximal inhibitory concentration: 3600 nM
Compound 4: middle estimate off by 1.6-fold (0.21 log units), on the low side; the measured number lies above the stated range.
By their numbers in this assay, from the lowest: compounds 2, 3, 1 and 4 (each within the scatter of the next).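

In this assay, the isopentyl group on the aromatic nitrogen stays within the scatter of all three earlier alkyl groups (a 1.6-fold higher number from compound 3 to compound 4 (0.19 log units; within the scatter)), (a 1.7-fold higher number from compound 2 to compound 4 (0.23 log units; within the scatter)) and (a 1.5-fold higher number from compound 1 to compound 4 (0.18 log units; within the scatter)). For the compounds shown here, these are the largest steps so far, yet the four alkyl compounds still show no separation, now with branching further along the chain as well. Nothing measured here speaks to the cause of these steps.

On these data alone, whether any group at this position gives a step beyond the scatter remains open. A chain ending in an amine or a carboxylic acid, or a benzyl group, would test this.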